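This account rests on a few compounds, and the source may have more. Where it says the series, first, only, none or still open, it means among the compounds named here.

Measured in an ADME assay on microsomes from liver (Homo sapiens) for metabolic stability, read by LC-MS, with NADPH named in the record, with a stated time of 60 min, tested at 1 uM, in the absence of a further agent; a lower number here means that less of the compound is left, a higher number that more of the compound is left:
- Compound 1 `COc1ccc(-c2c(C)nc3c(N4CC[C@@H](NC(C)=O)C4)cc(C)nn23)cc1OC`: > 95%
- Compound 2 `COc1ccc(-c2c(C)nc3c(N4CC[C@@H](NC(=O)OCc5ccccc5)C4)cc(C)nn23)cc1OC`: > 95%
- Compound 3 `COc1ccc(-c2c(C)nc3c(N4CCCC4)cc(C)nn23)cc1OC`: > 95%

All three entries are limits of the assay and not numbers.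

Compound 3 has only its limit of > 95% in this assay. Its two companions offer nothing firmer, which is the limit of > 95% in this assay, at which 3 of the 3 values shown sit.

The next compound, compound 4 `COc1ccc(-c2c(C)nc3c(N4CC[C@H](O)C4)cc(C)nn23)cc1OC`, differs from compound 3 by hydroxy in place of hydrogen on a saturated ring carbon, with hydroxy in place of hydrogen on a saturated ring carbon.

Two measured steps also exchange a group on a saturated ring carbon: a step that the two limits leave unreadable from compound 1 to compound 3 and a step that the two limits leave unreadable from compound 2 to compound 3. Neither has a readable size, so they set no number for the new step. They do show that acetamido, (benzyloxycarbonyl)amino and hydrogen all leave the result at the limit.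

No step beyond the scatter is therefore expected in this assay, and no direction can be assigned. The expected change is a number no higher from compound 3 to compound 4 (the limit leaves the size open). Compound 4 is estimated at 95%, with an expected range from 85% to 100%.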

Compound 4, percent of the compound remaining: > 95%
Compound 4: no number, only a limit; the forecaster's own chance of this, stated with the estimate: 65%; the middle value sits exactly at the limit.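

In this assay compound 4 gives > 95%, which is a limit of the assay and not a number. Among the compounds shown here, no step from compound 3 or compound 1 to compound 4 can be read. The compounds shown leave open whether hydroxy, acetamido, (benzyloxycarbonyl)amino and hydrogen on the saturated ring carbon differ at all in the percent of compound remaining.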